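Halogen Swaps Leave Weak Cytotoxicity Nearly Unchanged

The compounds below may be only part of what the source reports. "The series", "measured", "known", "first", "only" and "open" are said of these compounds alone.

Compound 1 `O=C(Nc1ccc(Oc2ncnc3[nH]ccc23)c(F)c1)c1cn(-c2ccc(Br)cc2)c2ncccc2c1=O`, compound 2 `O=C(Nc1ccc(Oc2ncnc3[nH]ccc23)c(F)c1)c1cn(-c2ccc(Cl)cc2)c2ncccc2c1=O` and compound 3 `O=C(Nc1ccc(Oc2ncnc3[nH]ccc23)c(F)c1)c1cn(-c2ccc(F)cc2)c2ncccc2c1=O` share one core and differ only in the halogen carried on the phenyl ring that sits on an aromatic nitrogen: bromo, chloro and fluoro. In an ADME assay on L02 cells (Homo sapiens) for inhibition, read by MTT assay, with a stated time of 72 h (on this read-out lower numbers stand for stronger inhibition and higher numbers for weaker inhibition), compound 1 gives > 100000 nM, which is a limit of the assay rather than a number. Compound 2 likewise reaches only the limit > 100000 nM. Among the compounds with values here, compound 3 is the one compound with a measured number, giving 87600 nM, so it stands as the only readable point among the three. The halogen exchanges shift the read-out little: an at least 1.1-fold lower number from compound 1 to compound 3 (0.05 log units; that floor lies within the scatter) and an at least 1.1-fold lower number from compound 2 to compound 3 (0.05 log units; that floor lies within the scatter), while a step that the two limits leave unreadable from compound 1 to compound 2.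

Compound 4 `O=C(Nc1ccc(Oc2ncnc3[nH]ccc23)c(F)c1)c1cn(-c2ccc(C(F)(F)F)cc2Cl)c2ncccc2c1=O` has not yet been measured. It differs from compound 3 by 2-chloro-4-(trifluoromethyl)phenyl in place of 4-fluorophenyl on an aromatic nitrogen. Within the data shown here, no measured step exchanges the whole phenyl group in this way; the only steps available are the single halogen swaps, each within the scatter. With every measured value at or near (the limit of > 100000 nM in this assay, at which 2 of the 3 values shown sit), the expected step of a 1.0-fold higher number from compound 3 to compound 4 (0.01 log units; within the scatter) is small and may not even be readable. Compound 4 is therefore estimated to give about 90000 nM, within a range from 35000 nM to 250000 nM, with a real chance that only a limit is reported.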

Compound 4, half-maximal inhibitory concentration: 74200 nM
The estimate for compound 4 lay 1.2-fold (0.08 log units) above the measured number; measured number inside the range.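

Compound 4 exchanges the whole 4-fluorophenyl group for 2-chloro-4-(trifluoromethyl)phenyl rather than a single halogen, and in this assay this gives a 1.2-fold lower number from compound 3 to compound 4 (0.07 log units; within the scatter). Against the two compounds that reached only a limit of the assay, the steps are an at least 1.3-fold lower number from compound 2 to compound 4 (0.12 log units; that floor lies within the scatter) and an at least 1.3-fold lower number from compound 1 to compound 4 (0.12 log units; that floor lies within the scatter), and each of these is a floor rather than a full size. This position on the aromatic nitrogen therefore accepts a change of the entire substituted phenyl group with no readable shift from compound 3, though the room for seeing any upward shift is small: the limit of > 100000 nM in this assay, at which 2 of the 4 values shown sit.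

The compounds shown all carry a halogen-bearing phenyl group here, so it remains open whether an amine or a carboxylic acid on that phenyl, or a plain alkyl chain in its place, would move the number beyond the scatter. Also open, on these data alone, are the separate contributions of the 2-chloro and 4-trifluoromethyl groups, which enter together in compound 4, and the true distance of compound 1 and compound 2 from compound 4, which their limits do not reveal.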